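The source may hold more compounds than are shown below. What is called first, only, known or untested is meant among the compounds shown, and "the series" means these compounds.

Working notes on the series. Among the compounds with values here, compound 3 `Cc1ccccc1-c1nc(CNc2ccc(C(=O)NO)cc2)n(-c2ccccc2)n1` carries a 2-methylphenyl group on an aromatic carbon of the shared core; in an assay on Sf9 cells for inhibition of protein deacetylase HDAC6 (Homo sapiens), read by fluorescence, with a stated time of 40 min, tested at 100 nM (a higher number here means more inhibition at the concentration tested (going by the name of the read-out), a lower number less inhibition), compound 3 gives 53.2%, which sits at the low end of the three numbers so far, with both other compounds within the scatter of it. Compound 1 `O=C(NO)c1ccc(NCc2nc(-c3ccc(Br)cc3)nn2-c2ccccc2)cc1` gives 54.7% in this assay, and compound 2 `O=C(NO)c1ccc(NCc2nc(-c3cccnc3)nn2-c2ccccc2)cc1` gives 57.7%. Every measured step in the set changes the group on this same aromatic carbon: a number 3 percentage points higher from compound 1 to compound 2 (within the scatter), a number 1.5 percentage points lower from compound 1 to compound 3 (within the scatter) and a number 4.5 percentage points lower from compound 2 to compound 3 (within the scatter). None of them left the scatter.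

Compound 4 `Cc1cccc(-c2nc(CNc3ccc(C(=O)NO)cc3)n(-c3ccccc3)n2)c1` differs from compound 3 by one change, (3-methylphenyl in place of 2-methylphenyl on an aromatic carbon). This is a swap of the same kind as the three measured ones, which all stayed within the scatter, so no step beyond the scatter is expected in this assay; the expected step is a number 1.8 percentage points higher from compound 3 to compound 4 (within the scatter). Compound 4 is therefore estimated at 55% in this assay, with a range from 42% to 68%.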

Compound 4, a percentage reported as inhibition, at one concentration (the size of the read-out at that concentration, not a potency): 64.1%
Compound 4: middle estimate off by 9.1 percentage points, on the low side; measured number inside the range.
By their numbers in this assay, from the lowest: compounds 3, 1, 2 and 4 (each within the scatter of the next, the first and the last beyond it).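

The series now has its first step at this aromatic carbon beyond the scatter, with a number 10.9 percentage points higher from compound 3 to compound 4 (beyond the scatter) in this assay, and the groups that swap there have the same atoms, joined differently. The other new steps, a number 6.4 percentage points higher from compound 2 to compound 4 (within the scatter) and a number 9.4 percentage points higher from compound 1 to compound 4 (within the scatter), both stay within the scatter, so 3-methylphenyl stands apart from 2-methylphenyl only, not from pyridin-3-yl or 4-bromophenyl. Nothing available on these compounds bears on why the two methylphenyl groups part.

Open, going by these compounds, is whether 4-methylphenyl would follow 3-methylphenyl or 2-methylphenyl, and whether a larger group such as 3-methoxyphenyl or a charged one such as 3-carboxyphenyl would keep the number of compound 4 at this carbon. Also open, on these data alone, is whether the gap between compound 3 and compound 4 would hold as a difference in potency, since each has a reading at one concentration only.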